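A few compounds are considered here, and "the series" means these few. Any claim that something is new, unique, unknown or untested is made for them only; others in the source may bear on it.

Measured so far in a functional assay on HeLa cells (Homo sapiens) for cytotoxicity, read by MTT assay; a higher number here means a weaker inhibitor, a lower number a stronger inhibitor:

- compound 1, `CC[C@@](C)(O)CC(=O)O[C@H](CC=C(C)C)C1=CC(=O)c2c(O)ccc(O)c2C1=O`: 17900 nM
- compound 2, `CC(C)=CC[C@@H](OC(=O)C1CCCO1)C1=CC(=O)c2c(O)ccc(O)c2C1=O`: 17000 nM
- compound 3, `CC[C@](C)(O)CC(=O)O[C@H](CC=C(C)C)C1=CC(=O)c2c(O)ccc(O)c2C1=O`: 30200 nM

Compound 3 gives the highest of the three numbers, yet its gaps to the other two are both within the scatter. The step of a 1.7-fold higher number from compound 1 to compound 3 (0.23 log units; within the scatter) rests on (the fact that compounds 1 and 3 differ only in the configuration as drawn), so the stereocentre alone does not move the read-out noticeably. The two ester swaps, a 1.1-fold lower number from compound 1 to compound 2 (0.02 log units; within the scatter) and a 1.8-fold higher number from compound 2 to compound 3 (0.25 log units; within the scatter), exchange one acyl group for another at the carbonyl carbon and also stay within the scatter.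

Compound 4, `CC(C)=CC[C@@H](OCC(C)O)C1=CC(=O)c2c(O)ccc(O)c2C1=O`, differs from compound 3 in that (2-hydroxypropyl in place of (2-hydroxy-2-methylbutyl)carbonyl on an oxygen on a saturated carbon). This change goes further than the measured steps: it removes the carbonyl and leaves a bare ether linkage to the shorter 2-hydroxypropyl chain, which none of the three measured compounds contains. For the measured compounds named here, the steps that bear on it, both changes of the acyl side chain, were flat, so no step beyond the scatter is expected in either direction, though the wider range reflects that the carbonyl itself has not been varied. Compound 4 is therefore estimated at 25000 nM, between 8000 nM and 80000 nM, an expected step of a 1.2-fold lower number from compound 3 to compound 4 (0.08 log units; within the scatter).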

Compound 4, half-maximal inhibitory concentration: 24700 nM
Beside the measured number, compound 4's estimate is 1.0-fold (0.01 log units) above it; the measured number falls inside the stated range.
By their numbers in this assay, from the lowest: compounds 2, 1, 4 and 3 (each within the scatter of the next).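

In this assay the steps of a 1.2-fold lower number from compound 3 to compound 4 (0.09 log units; within the scatter) and a 1.5-fold higher number from compound 2 to compound 4 (0.16 log units; within the scatter) and a 1.4-fold higher number from compound 1 to compound 4 (0.14 log units; within the scatter) show that the read-out stays flat when the ester on this oxygen gives way to an ether carrying 2-hydroxypropyl. The earlier compounds varied only the acyl group and all kept its carbonyl, so compound 4 is the first to show that, among these four compounds, neither that carbonyl nor the larger acyl side chain is required to keep the number in this range. No measurement shown accounts for why the read-out holds across this change.

The compounds shown leave open whether any group on this oxygen can move the number beyond the scatter, for example a chain ending in an amine or a carboxylic acid, or a longer alkyl chain. They also leave open whether the hydroxyl of the 2-hydroxypropyl chain matters, as a plain propyl ether is not among them.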